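This account rests on a few compounds, and the source may have more. Where it says the series, first, only, none or still open, it means among the compounds named here.

Compound 1, `COc1ccc(Cn2nc(Nc3cc(C)[nH]n3)c3ccccc3c2=O)cc1`, sits second highest among the three numbers in hand. In a functional assay on HCT-116 cells (Homo sapiens) for cytotoxicity, read by CellTiter-Glo, with a stated time of 5 days (a lower number here means a stronger inhibitor, a higher number a weaker inhibitor), compound 1 gives 1200 nM. Compound 2, `Cc1cc(Nc2nn(Cc3ccc(S(C)(=O)=O)cc3)c(=O)c3ccccc23)n[nH]1`, gives 1700 nM in this assay, and compound 3, `Cc1cc(Nc2nn(Cc3cc(F)ccc3F)c(=O)c3ccccc23)n[nH]1`, gives 570 nM. The two measured steps from compound 1 read a 1.4-fold higher number from compound 1 to compound 2 (0.15 log units; within the scatter) and a 2.1-fold lower number from compound 1 to compound 3 (0.32 log units; beyond the scatter).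

Compound 4, `Cc1cc(Nc2nn(Cc3ccc([N+](=O)[O-])cc3)c(=O)c3ccccc23)n[nH]1`, has not been measured. It differs from compound 1 by nitro in place of methoxy on an aromatic carbon. The step from compound 1 to compound 2 bears most directly on this change, since it also exchanges the methoxy on that aromatic carbon for another group and stayed within the scatter. The step from compound 1 to compound 3 reworks the ring pattern more broadly and is the less relevant guide. Compound 4 is therefore expected to show no step beyond the scatter, with an estimated change of no change at the digits printed from compound 1 to compound 4 (within the scatter). Compound 4 is estimated at 1200 nM in this assay, within a range from 500 nM to 2800 nM.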

Compound 4, half-maximal inhibitory concentration: 1400 nM
Beside the measured number, compound 4's estimate is 1.2-fold (0.07 log units) below it, and the stated range covers the measured number.
By their numbers in this assay, from the lowest: compound 3; then compounds 1, 4 and 2 (each within the scatter of the next).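

In this assay nitro now joins methylsulfonyl as a replacement for methoxy on this aromatic carbon, and the change reads a 1.2-fold higher number from compound 1 to compound 4 (0.07 log units; within the scatter), while the exchange of the two replacements reads a 1.2-fold lower number from compound 2 to compound 4 (0.08 log units; within the scatter), so methoxy, methylsulfonyl and nitro at this place cannot be told apart by their numbers. The 2,5-difluorophenyl group gives a distinction that this new comparison confirms, though only modestly: the exchange for 4-nitrophenyl reads a 2.5-fold higher number from compound 3 to compound 4 (0.39 log units; beyond the scatter). Nothing measured here explains either finding.

As far as these compounds go, whether an amine or a carboxylic acid on this aromatic carbon would also leave the number within the scatter remains open. Also open, from the compounds shown here alone, is how a phenyl group with a single fluorine, or with no added group at all, would compare with compound 3.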